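Compound 2 to compound 3: one added methyl

The source may report more compounds than this note shows. Statements on the series, on what has been measured and on what is new or still open speak of the compounds shown alone.

In a functional assay on MDA-MB-231 cells (Homo sapiens) for inhibition, read by MTT assay, with a stated time of 48 h (on this read-out higher numbers stand for weaker inhibition of growth and lower numbers for stronger inhibition of growth), compound 1 (`S=C(NCc1ccccc1)Nc1ccc2ncnc(Nc3ccccc3Br)c2c1`) gives > 30000 nM as a limit and not a number. Among the compounds with values here, compound 2 (`Cc1cccc(Nc2ncnc3ccc(NC(=S)NCc4ccccc4)cc23)c1`) gives 19500 nM and holds the only actual number so far. Compound 3 (`Cc1cccc(Nc2ncnc3ccc(NC(=S)NCc4ccccc4)cc23)c1C`) turns 3-methylphenyl into 2,3-dimethylphenyl (methyl in place of hydrogen on an aromatic carbon), with the new methyl ortho to a large group and ortho to a methyl group. Within the data shown here, the one measured step, an at least 1.5-fold lower number from compound 1 to compound 2 (0.18 log units; that floor lies within the scatter) on that same nitrogen, starts from the limit of > 30000 nM in this assay, at which 1 of the 2 values shown sits, and offers no firm size, so no change beyond the scatter is expected. The expected step is a 1.0-fold higher number from compound 2 to compound 3 (0.01 log units; within the scatter) as a working estimate. In this assay compound 3 is expected at 20000 nM with an estimated range from 9000 nM to 30000 nM for now.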

Compound 3, concentration for 50% growth inhibition: 28700 nM
Compound 3: middle estimate off by 1.4-fold (0.16 log units), on the low side; low and high end bracket the measured number.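

In this assay, the added methyl, ortho to a large group and ortho to a methyl group, gives a 1.5-fold higher number from compound 2 to compound 3 (0.17 log units; within the scatter), so methyl in place of hydrogen at this position brings no change beyond the scatter. Against the 2-bromophenyl of compound 1, the 2,3-dimethylphenyl gives an at least 1.0-fold lower number from compound 1 to compound 3 (0.01 log units; that floor lies within the scatter), and this reads only as a floor because compound 1 gives a limit and not a number: the limit of > 30000 nM in this assay, at which 1 of the 3 values shown sits.

From the compounds shown here alone, whether an amine, a methoxy or a carboxylic acid at this position would move the number beyond the scatter remains open. So does whether the same methyl would behave alike on other aryl groups on that nitrogen.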